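Shortening the side chain of a tetrahydropyran series

The source may report more compounds than this note shows. Statements on the series, on what has been measured and on what is new or still open speak of the compounds shown alone.

Compound 1 `O[C@@H](c1ccccc1)[C@H]1CO[C@H](c2ccccc2)[C@@H](C/C=C/C2CCCCC2)C1` is one of three related compounds tested in a functional assay on HeLa cells (Homo sapiens) for cytotoxicity, read by WST assay, with a stated time of 48 h (on this read-out higher numbers stand for weaker inhibition and lower numbers for stronger inhibition), where compound 1 gives 6440 nM. Compound 2 `O=[N+]([O-])c1ccccc1/C=C/C[C@H]1C[C@@H]([C@@H](O)c2ccccc2)CO[C@@H]1c1ccccc1` gives 11800 nM and compound 3 `O=[N+]([O-])c1ccc(/C=C/C[C@H]2C[C@@H]([C@@H](O)c3ccccc3)CO[C@@H]2c2ccccc2)cc1` gives 12400 nM. Compound 1 has the lowest number of the three, but the steps of a 1.8-fold higher number from compound 1 to compound 2 (0.26 log units; within the scatter) and a 1.9-fold higher number from compound 1 to compound 3 (0.28 log units; within the scatter) are both within the scatter, as is a 1.1-fold higher number from compound 2 to compound 3 (0.02 log units; within the scatter), so no order among them can be claimed.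

Compound 4 `C=CC[C@H]1C[C@@H]([C@@H](O)c2ccccc2)CO[C@@H]1c1ccccc1` has not yet been measured. Its difference from compound 1 is vinyl in place of 2-cyclohexylethenyl on a saturated chain carbon bound to a saturated ring carbon. Within the data shown here, the measured steps replace the cyclohexyl with a 2-nitrophenyl or a 4-nitrophenyl while keeping the chain; none of them removes the terminal ring altogether, so no step bears directly on this change. From the compounds shown here alone, all three compounds with a ring at the chain end sit close together, which suggests the ring itself contributes little distinction among them, but its loss is untested. Compound 4 is therefore expected to give roughly a 1.9-fold higher number from compound 1 to compound 4 (0.27 log units; within the scatter), most likely a weaker number, and its estimated value is 12000 nM with a range from 5000 nM to 35000 nM.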

Compound 4, half-maximal inhibitory concentration: 25400 nM
Beside the measured number, compound 4's estimate is 2.1-fold (0.33 log units) below it; the measured number falls inside the stated range.
By their numbers in this assay, from the lowest: compounds 1, 2 and 3 (each within the scatter of the next); then compound 4.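

Of the steps shown, only the cut from 2-cyclohexylethenyl to vinyl moves the number beyond the scatter in this assay, with a 3.9-fold higher number from compound 1 to compound 4 (0.60 log units; beyond the scatter), a modest step towards weaker inhibition. The exchanges of cyclohexyl for 2-nitrophenyl or 4-nitrophenyl stayed within the scatter, whereas this change removes the terminal ring altogether, so what sits at this chain end is not fully interchangeable. Nothing measured here accounts for the shift.

In this step the ring and the chain length go together, and the compounds shown do not say which of them matters. A hexenyl chain with an open end would help to separate the two, and an unsubstituted phenyl or an amine at the chain end would show how far the end group can vary.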